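From phenyl to 4-methylbenzyl on the amide nitrogen

The source may hold more compounds than are shown below. What is called first, only, known or untested is meant among the compounds shown, and "the series" means these compounds.

In a functional assay on CCRF-CEM cells (Homo sapiens) for inhibition, read by MTT assay, with a stated time of 72 h (on this read-out lower numbers stand for stronger inhibition and higher numbers for weaker inhibition), compound 1 (`C=C(Br)C(=O)Nc1cccc(/C=C/C(=O)Nc2ccccc2)c1`) gives 190 nM and sits level with compound 3 (`C=C(Br)C(=O)Nc1cccc(/C=C/C(=O)Nc2ccc(C)cc2)c1`) at 270 nM at the low end of the three numbers, while compound 2 (`C=C(Br)C(=O)Nc1cccc(/C=C/C(=O)Nc2ccc(F)cc2)c1`) stands far off at 16600 nM in the same read-out.

The step to compound 4 (`C=C(Br)C(=O)Nc1cccc(/C=C/C(=O)NCc2ccc(C)cc2)c1`) is 4-methylbenzyl in place of phenyl on an amide-type nitrogen and reads as 4-methylbenzyl in place of phenyl on an amide-type nitrogen.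

Only the ring substitution steps bear on this change, and only in part. Methyl in place of hydrogen gave a 1.4-fold higher number from compound 1 to compound 3 (0.15 log units; within the scatter) and stays within the scatter, so the methyl group alone offers no ground for expecting a shift. Fluoro in place of hydrogen gave an 87-fold higher number from compound 1 to compound 2 (1.94 log units; beyond the scatter) and methyl in place of fluoro gave a 61-fold lower number from compound 2 to compound 3 (1.79 log units; beyond the scatter) as large steps, so one exchange on this aromatic ring can move the number strongly. Among the measured compounds shown here, no measured compound carries a benzyl group on the amide nitrogen, and that part of the change remains untested.

An estimated 3.2-fold higher number from compound 1 to compound 4 (0.50 log units; beyond the scatter) is expected in this assay as a moderate move toward weaker inhibition, with wide uncertainty. The estimated value for compound 4 is 600 nM with an expected range from 120 nM to 5000 nM in this read-out.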

Compound 4, half-maximal inhibitory concentration: 550 nM
Compound 4: middle estimate off by 1.1-fold (0.04 log units), on the high side; measured number inside the range.
By their numbers in this assay, from the lowest: compounds 1 and 3 (each within the scatter of the next); then compound 4; then compound 2.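

Working note on the amide nitrogen: in this assay the change to 4-methylbenzyl brings a 2.9-fold higher number from compound 1 to compound 4 (0.46 log units; beyond the scatter) as a modest step, so this position accepts a group larger than phenyl at the cost of only a limited shift in the number. Among the compounds shown here, with the ring methyl present on both sides, the comparison of the 4-methylphenyl and 4-methylbenzyl groups gives a 2.0-fold higher number from compound 3 to compound 4 (0.31 log units; beyond the scatter) as a second modest step, the first reading on the benzyl form of this group, while a 30-fold lower number from compound 2 to compound 4 (1.48 log units; beyond the scatter) as a large step leaves compound 2 as the clear outlier of the four. The data shown hold no measurement that would explain any of these steps.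

From the compounds shown here alone, two questions remain open. One is whether 4-fluorobenzyl on the amide nitrogen would carry the same large penalty seen with 4-fluorophenyl, or whether that penalty belongs to the directly attached ring alone. The other is how unsubstituted benzyl, a longer chain such as 2-phenylethyl, or a ring bearing an amine or a carboxylic acid would read at this nitrogen.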